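Fluorines on the benzyl group of compound 2

The source may report more compounds than this note shows. Statements on the series, on what has been measured and on what is new or still open speak of the compounds shown alone.

Of the compounds shown here, two have been tested in a functional assay on MCF7 cells (Homo sapiens) for antiproliferative activity, read by cell counting, with a stated time of 4 days (on this read-out higher numbers stand for weaker inhibition and lower numbers for stronger inhibition), so far, compound 1 (`CCOC(=O)CN(Cc1ccc(F)cc1)c1ccc2c(c1)OC(C)(COc1ccc(C#N)cc1)CN2C`) and compound 2 (`CCOC(=O)C(=O)N(Cc1ccccc1)c1ccc2c(c1)OC(C)(CO)CN2C`). Compound 1 gives > 100000 nM as a limit, not a number. Compound 2 gives > 100000 nM as a limit too, and so stands at the limit of > 100000 nM in this assay, at which 2 of the 2 values shown sit, without a number. Compound 3 (`CCOC(=O)C(=O)N(Cc1cc(F)cc(F)c1)c1ccc2c(c1)OC(C)(CO)CN2C`) has 3,5-difluorophenyl in place of phenyl on a saturated chain carbon bound to an amide-type nitrogen. With compound 2 itself at > 100000 nM as a limit, no change beyond the scatter is expected in this assay and no direction is favoured. The expected size of a number no higher from compound 2 to compound 3 (the limit leaves the size open) is small. For compound 3 the estimated value is 100000 nM with an expected range of 30000 nM to 200000 nM for the coming measurement.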

Compound 3, half-maximal inhibitory concentration: 45000 nM
Compound 3: the middle estimate sits 2.2-fold (0.35 log units) above what was measured; the measured number falls inside the stated range.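

In this assay, for the compounds shown here, 3,5-difluorophenyl in place of phenyl on a saturated chain carbon bound to an amide-type nitrogen gives the first readable step, an at least 2.2-fold lower number from compound 2 to compound 3 (0.34 log units; beyond the scatter), so this position can respond to ring substitution. The true size of the step stays open because compound 2 carries only a limit: the limit of > 100000 nM in this assay, at which 2 of the 3 values shown sit.

The compounds shown do not separate the contribution of each fluorine. From the compounds shown here alone, how a chlorine or methoxy group on this ring, or a carboxylic acid in place of the ethyl ester, would read remains open.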